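The compounds below may be only part of what the source reports. "The series", "measured", "known", "first", "only" and "open" are said of these compounds alone.

The measured compounds:
Compound 1 `Cc1nc(-c2nc[nH]n2)ccc1-c1cnc2c(n1)N(CCC1CCOCC1)C(=O)CN2` gives 76% in an ADME assay on S9 fraction from liver (Rattus norvegicus) for metabolic stability, with a stated time of 60 min; a lower number here means that less of the compound is left, a higher number that more of the compound is left.
Compound 2 `COCCN1C(=O)CNc2ncc(-c3ccc(-c4nc[nH]n4)nc3C)nc21` gives 91% in this assay.

Among the measured compounds shown here, on these two numbers compound 1 stands lowest, with compound 2 its only neighbour, a number 15 percentage points higher from compound 1 to compound 2 (beyond the scatter). Compound 3 `CO[C@H]1CC[C@@H](CN2C(=O)CNc3ncc(-c4ccc(-c5nc[nH]n5)nc4C)nc32)CC1` has not yet been measured. It differs from compound 1 in one place: 4-methoxycyclohexyl in place of (oxan-4-yl)methyl on a saturated chain carbon bound to an amide-type nitrogen in a ring. For the measured compounds named here, only one measured step bears on this change, and only in part: a number 15 percentage points higher from compound 1 to compound 2 (beyond the scatter), where methoxy took the place of oxan-4-yl on a saturated chain carbon, two bonds along the chain from an amide-type nitrogen in a ring. Going by the values given here, the change to compound 3 likewise brings in a methoxy and removes the six-membered non-aromatic ring with one hetero atom, yet it also brings in a six-membered non-aromatic ring of carbon only, and read one bond further out it is 2-(oxan-4-yl)ethyl giving way to (4-methoxycyclohexyl)methyl, a combination no measured pair covers. Among the compounds with values here, the one step gives a direction, toward more compound remaining, but no firm size; a step within the scatter is as plausible as a modest rise. For compound 3 the expected value in this assay is 80%, in the range 62% to 93%. That estimate means an expected step of a number 4 percentage points higher from compound 1 to compound 3 (within the scatter).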

Compound 3, percent of the compound remaining: 39%
The estimate for compound 3 lay 41 percentage points above the measured number, outside the stated range (below it).
By their numbers in this assay, from the lowest: compound 3; then compound 1; then compound 2.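

In this assay, the group on a saturated chain carbon bound to an amide-type nitrogen in a ring can move the number down as well as up: 4-methoxycyclohexyl in place of (oxan-4-yl)methyl gives a number 37 percentage points lower from compound 1 to compound 3 (beyond the scatter), and 4-methoxycyclohexyl in place of methoxymethyl gives a number 52 percentage points lower from compound 2 to compound 3 (beyond the scatter). Bringing in a methoxy therefore does not by itself go with more compound remaining, since compound 2 and compound 3 both carry one yet stand at opposite ends of the three numbers. Compound 3 alone has a six-membered non-aromatic ring of carbon only in this place, while compound 1 has a ring with a hetero atom and compound 2 has an open chain, but nothing measured here explains the drop.

No pair shown separates the carbon-only ring from the methoxy on it, so a plain cyclohexyl or a 4-hydroxycyclohexyl in the same place would be needed to tell which of the two goes with the lower number. Going by these compounds, compound 3 also has two defined stereocentres, and how its other stereoisomer, with the methoxy on the opposite face of the ring, would behave in this assay remains open.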